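Ethoxy to hydroxy at the shared core of compound 1

A few compounds are considered here, and "the series" means these few. Any claim that something is new, unique, unknown or untested is made for them only; others in the source may bear on it.

Measured so far:
compound 1: `CCO[C@]1(c2ccc(OCc3c(-c4c(Cl)cccc4Cl)noc3C3CC3)cc2Cl)C[C@H](c2cccc(C(=O)O)c2)C1` — 277 nM
compound 2: `Clc1cc(OCc2c(-c3c(Cl)cccc3Cl)noc2C2CC2)ccc1C1CC1c1ccc(-c2nnn[nH]2)nc1` — 131 nM

Both compounds were read in an assay on isolated protein for agonist activity at Bile acid receptor (Homo sapiens), read by FRET; a lower number here means that less compound is needed, a higher number that more compound is needed for the effect. Compound 1 stands with the highest of the two numbers; its nearest neighbour is compound 2, whose number is lower by a gap beyond the usual scatter. The two compounds differ in several places at once, so nothing can be read from that gap about any single change.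

Compound 3, `O=C(O)c1cccc([C@H]2C[C@](O)(c3ccc(OCc4c(-c5c(Cl)cccc5Cl)noc4C4CC4)cc3Cl)C2)c1`, differs from compound 1 by hydrogen in place of ethyl on an oxygen on a saturated carbon; cut one bond further out, the difference reads ethoxy to hydroxy. Within the data shown here, no pair of measured compounds shows this change, so the step has no precedent here. The step from compound 1 to compound 3 in this assay is expected to be a 1.4-fold higher number from compound 1 to compound 3 (0.14 log units; within the scatter), a small rise in the number, possibly no more than the scatter. For compound 3 the estimate in this assay is 380 nM, with a range from 130 nM to 1100 nM.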

Compound 3, half-maximal effective concentration: 29 nM
Estimate against measurement, compound 3: 13-fold (1.12 log units) above; the whole stated range lies above it.
By their numbers in this assay, from the lowest: compound 3; then compound 2; then compound 1.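

In this assay, among these compounds, hydrogen in place of ethyl on the oxygen on a saturated carbon gives a 9.6-fold lower number from compound 1 to compound 3 (0.98 log units; beyond the scatter), the first step that can be read as a single change. It is beyond the scatter, so this position clearly matters to the number: ethoxy to hydroxy, with the rest of the core of compound 1 unchanged, means less compound is needed for the effect. No measurement at hand offers a reason for this step.

Only ethoxy and hydroxy are shown here, so it remains open whether the number follows the free hydroxy or simply the loss of the ethyl, a question that methoxy or an amine at this carbon would address. Also open, going by these compounds, is whether the step would hold with a group other than the carboxylic acid elsewhere on the core.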